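Amide aryl variation in the cinnamamide series: compound 4

The source may report more compounds than this note shows. Statements on the series, on what has been measured and on what is new or still open speak of the compounds shown alone.

Measured compounds, with their values in an in vitro ADME assay on microsomes from liver (Mus musculus) for pharmacokinetics, read by LC-MS, with a stated time of 10 min, tested at 1 uM; on this read-out higher numbers stand for fast clearance and lower numbers for slow clearance:
compound 1 `CN1C[C@H](C(=O)Nc2ccc(C(F)(F)F)cc2)[C@@H](c2ccc(/C=C/C(=O)Nc3ccccc3N)cc2)C1` gives 23 mL/min/kg
compound 2 `CN1C[C@H](C(=O)Nc2cccc(F)c2)[C@@H](c2ccc(/C=C/C(=O)Nc3ccccc3N)cc2)C1` gives 56 mL/min/kg
compound 3 `Cc1cccc(NC(=O)[C@H]2CN(C)C[C@@H]2c2ccc(/C=C/C(=O)Nc3ccccc3N)cc2)c1` gives 74 mL/min/kg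

Compound 3 holds the highest of the three numbers in this assay. The nearest step is a 1.3-fold higher number from compound 2 to compound 3 (0.12 log units; within the scatter), so those two cannot be ordered. Against compound 1 the step is a 3.2-fold higher number from compound 1 to compound 3 (0.51 log units; beyond the scatter), and compound 1 also sits apart from compound 2 by a 2.4-fold higher number from compound 1 to compound 2 (0.39 log units; beyond the scatter).

Compound 4 `CN1C[C@H](C(=O)Nc2ccccn2)[C@@H](c2ccc(/C=C/C(=O)Nc3ccccc3N)cc2)C1` is not yet measured. Its difference from compound 3 is pyridin-2-yl in place of 3-methylphenyl on an amide-type nitrogen. All three measured steps concern the same amide-type nitrogen, so they bear on this change, but none of them introduces a ring hetero atom: the step from fluoro to methyl on an aromatic carbon stayed within the scatter, while the two steps away from 4-(trifluoromethyl)phenyl were modest. Among the compounds with values here, a pyridin-2-yl ring has no measured precedent here, so only a loose expectation is possible. The number for compound 4 is expected to move by about a 1.2-fold lower number from compound 3 to compound 4 (0.09 log units; within the scatter), which is within the scatter, leaving it near compound 3 and compound 2 rather than near compound 1. In this assay compound 4 is therefore estimated at 60 mL/min/kg, with a range from 30 mL/min/kg to 115 mL/min/kg.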

Compound 4, clearance: 40 mL/min/kg
The estimate for compound 4 lay 1.5-fold (0.18 log units) above the measured number; measured number inside the range.
By their numbers in this assay, from the lowest: compounds 1, 4, 2 and 3 (each within the scatter of the next, the first and the last beyond it).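

In this assay, within the data shown here, pyridin-2-yl is the first ring on this amide-type nitrogen with a hetero atom, and the comparison with 3-methylphenyl reads as a 1.9-fold lower number from compound 3 to compound 4 (0.27 log units; within the scatter) while that with 3-fluorophenyl reads as a 1.4-fold lower number from compound 2 to compound 4 (0.15 log units; within the scatter) and neither can be ordered. The comparison with 4-(trifluoromethyl)phenyl reads as a 1.7-fold higher number from compound 1 to compound 4 (0.24 log units; within the scatter) and also stays within the scatter, so compound 4 cannot be separated from any of the three earlier compounds, even though compound 1 stands apart from both compound 2 and compound 3 beyond the scatter. No measurement shown here accounts for these numbers.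

Open, as far as these compounds go, is whether the place of the ring nitrogen matters at all, which pyridin-3-yl and pyridin-4-yl on the same amide-type nitrogen would test, and whether a trifluoromethyl group on a pyridin-2-yl ring would read nearer compound 1 than compound 4 does. Also open is how a ring carrying an amine or a carboxylic acid would read on this nitrogen, since every ring shown bears either a single small group or none.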